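A few compounds are considered here, and "the series" means these few. Any claim that something is new, unique, unknown or untested is made for them only; others in the source may bear on it.

Measured compounds in a functional assay on SGC-7901 cells (Homo sapiens) for antiproliferative activity, read by MTT assay, with a stated time of 24 h; on this read-out higher numbers stand for weaker inhibition and lower numbers for stronger inhibition:
Compound 1 `Cc1ccccc1NNC(=O)c1cccc(NS(=O)(=O)c2cnc(O)nc2O)c1` gives > 20000 nM, which is a limit of the assay rather than a number.
Compound 2 `O=C(NNc1ccccc1Cl)c1ccccc1NS(=O)(=O)c1cnc(O)nc1O` gives > 20000 nM, likewise a limit rather than a number.

Among the measured compounds shown here, compound 1 therefore stands at the limit, and so does the only other value shown (the limit of > 20000 nM in this assay, at which 2 of the 2 values shown sit). For the measured compounds named here, no two measured compounds differ in a single place, so there is no measured step to follow. Compound 3 `O=C(NNC(=O)c1cccc(NS(=O)(=O)c2cnc(O)nc2O)c1)c1cccc(Cl)c1` is the compound still to be tested in this assay. It differs from compound 1 in one place: (3-chlorophenyl)carbonyl in place of 2-methylphenyl on an amine nitrogen. Both measured compounds are too weak for a number to be read, and nothing among them points to this change bringing the value into the measurable range. The step expected in this assay is a step that the limit leaves unreadable from compound 1 to compound 3, which is no change beyond the scatter. For compound 3 the estimate is 30000 nM, within a range of 6000 nM to 150000 nM, and most likely again only a limit will be reported.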

Compound 3, half-maximal inhibitory concentration: 7310 nM
Compound 3: the middle estimate sits 4.1-fold (0.61 log units) above what was measured; measured number inside the range.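

In this assay, (3-chlorophenyl)carbonyl in place of 2-methylphenyl on an amine nitrogen gives an at least 2.7-fold lower number from compound 1 to compound 3 (0.43 log units; beyond the scatter). This shows that a change at this one place on the core of compound 1 can bring a compound into the measurable range, which neither earlier compound showed. The full size of the step cannot be read because compound 1 gives only a limit, not a number: the limit of > 20000 nM in this assay, at which 2 of the 3 values shown sit.

The change brings in a carbonyl and a chlorine together and replaces the methyl-bearing ring, so the compounds shown do not separate what each part contributes. From the compounds shown here alone, whether a plain phenylcarbonyl without the chlorine, or a small acetyl group, would also give a measurable value remains open.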